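A Methoxy Group Enters the Aryl Ring of Compound 2

The source may report more compounds than this note shows. Statements on the series, on what has been measured and on what is new or still open speak of the compounds shown alone.

The two measured compounds, with their values in a functional assay on HT-29 cells (Homo sapiens) for inhibition, read by sulforhodamine B assay, with a stated time of 48 h; on this read-out higher numbers stand for weaker inhibition of growth and lower numbers for stronger inhibition of growth:

Compound 1 `CC1=CC[C@H](C(C)(C)NC(=S)N/N=C/c2ccccc2)CC1` gives 8800 nM
Compound 2 `CC1=CC[C@H](C(C)(C)NC(=S)N/N=C(\C)c2ccccc2)CC1` gives 29500 nM

Among these two numbers compound 2 stands highest. Compound 1 gives the lower number in this assay, and the gap between the two lies beyond the usual scatter of repeated measurements, so compound 2 is the weaker of the pair on this read-out. Between compound 1 and compound 2 the only difference is the group on the imine carbon, and no further pair is available to show what a change on the aryl ring does.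

Compound 3 `COc1ccc(/C(C)=N/NC(=S)NC(C)(C)[C@H]2CC=C(C)CC2)cc1` is the next compound in line. It differs from compound 2 in one place: methoxy in place of hydrogen on an aromatic carbon. Within the data shown here, no measured pair in this set carries that change, so the expectation rests on the structural change alone. A step from compound 2 to compound 3 of the size a 1.5-fold lower number from compound 2 to compound 3 (0.17 log units; within the scatter) is expected in this assay, that is, none that clearly rises above the scatter. For compound 3 the estimated value in this assay is 20000 nM, with a range from 7000 nM to 60000 nM.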

Compound 3, concentration for 50% growth inhibition: 18700 nM
Beside the measured number, compound 3's estimate is 1.1-fold (0.03 log units) above it, and the stated range covers the measured number.
By their numbers in this assay, from the lowest: compound 1; then compounds 3 and 2 (each within the scatter of the next).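

In this assay, among these compounds, the change from phenyl to 4-methoxyphenyl gives the first reading on the aryl ring in this set: a 1.6-fold lower number from compound 2 to compound 3 (0.20 log units; within the scatter), a step that stays within the usual scatter of repeated measurements. On this single pair, methoxy in place of hydrogen, para to a large group on the aromatic ring, makes no difference that this read-out can resolve, so the two compounds cannot be told apart here. The measurements offer no account of why that is so, and nothing at hand bears on the result.

Still open, on these data alone, is whether a different group at this place, such as an amine, a carboxylic acid or a longer alkoxy chain, would give a step beyond the scatter, and whether methoxy on another carbon of the ring would read the same. As far as these compounds go, it is also open whether the same change would leave the number as little altered on compound 1, which has hydrogen rather than methyl on the imine carbon.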